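Series notes: hydroxy to cyclopropyl on the aryl ring

The compounds below may be only part of what the source reports. "The series", "measured", "known", "first", "only" and "open" are said of these compounds alone.

Going by the values given here, compound 1 `CC1CC/C(=N\Nc2ccc(O)cc2)c2ncc(C(=O)O)c(=O)n21` is the reference among the two measured members. In a functional assay on the whole organism for inhibition, with Rattus norvegicus as the target (on this read-out lower numbers stand for an effect already at smaller amounts and higher numbers for an effect only at larger amounts of compound), compound 1 gives 1.7 umol/kg, the lowest of the two numbers. Compound 2 `C[C@H]1CC/C(=N\Nc2ccc(O)cc2)c2ncc(C(=O)O)c(=O)n21` has the same atoms and bonds; in this assay compound 2 gives 111 umol/kg. The step of a 65-fold higher number from compound 1 to compound 2 (1.81 log units; beyond the scatter) is the only measured one, and the two compounds are set apart solely by the fact that one of compounds 1 and 2 is drawn with a defined configuration and the other without, at the place where they differ.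

Compound 3 `CC1CC/C(=N\Nc2ccc(C3CC3)cc2)c2ncc(C(=O)O)c(=O)n21` differs from compound 1 by cyclopropyl in place of hydroxy on an aromatic carbon. Among the compounds with values here, no measured step touches this aromatic carbon or the hydroxy; the single step concerns the stereocentre at the saturated ring carbon and so gives no guide to the size or direction of the step in this assay. The exchange removes one hydrogen-bond donor and one hydrogen-bond acceptor as counted, and a moderate rise in the number is expected rather than none, with a wide range to match the absence of a comparable step.

For compound 3 the estimate in this assay is 5 umol/kg, between 1 umol/kg and 30 umol/kg. The expected step of a 2.9-fold higher number from compound 1 to compound 3 (0.47 log units; beyond the scatter) is offered with this broad range.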

Compound 3, dose for 50% inhibition: 41.1 umol/kg
Compound 3: middle estimate off by 8.2-fold (0.91 log units), on the low side; measured number above the stated range.
By their numbers in this assay, from the lowest: compound 1; then compound 3; then compound 2.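

Cyclopropyl in place of hydroxy on an aromatic carbon gives a 24-fold higher number from compound 1 to compound 3 (1.38 log units; beyond the scatter) in this assay, so the series responds strongly to a change on the aryl ring, where the number had not been tested before. The earlier step concerned only the stereocentre at the saturated ring carbon, whereas this one shows that, with that centre drawn alike, the aromatic carbon para to a large group tolerates this exchange poorly on this read-out. The information in hand does not bear on what drives this step, and the exchange alters several counted features at once, as the hydroxy brings a hydrogen-bond donor and acceptor and cyclopropyl brings neither, but adds a three-membered ring of carbon only.

Going by these compounds, it remains open whether the hydroxy itself matters or whether cyclopropyl is the problem, a question that methoxy, an amine or a plain methyl on the same aromatic carbon would help to separate. Also open, on these data alone, is whether the step keeps its size when the saturated ring carbon carries the configuration drawn in compound 2.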